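The source may report more compounds than this note shows. Statements on the series, on what has been measured and on what is new or still open speak of the compounds shown alone.

Three compounds of the series have been run in a functional assay on A2780 cells (Homo sapiens) for inhibition, read by trypan blue exclusion, with a stated time of 72 h; on this read-out higher numbers stand for weaker inhibition of growth and lower numbers for stronger inhibition of growth. Compound 1 `CCCn1c(-c2ccc(O)cc2)c(C)c2ccccc21` gives 9000 nM. Compound 2 `CCCn1c(-c2ccc(O)c(O)c2)c(C)c2cc(O)ccc21` gives 8400 nM, and compound 3 `Cc1c(-c2ccc(O)c(O)c2)n(CCCCOc2ccccc2)c2ccc(O)cc12` gives 4300 nM. Compound 1 holds the highest of the three numbers; its gap to compound 2 lies within the scatter, its gap to compound 3 beyond it. The difference between the core of compound 1 and the core of compound 2 is not broken down here.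

Compound 3 differs from compound 2 in one place: phenoxymethyl in place of hydrogen on a saturated chain carbon, three bonds along the chain from an aromatic nitrogen. That step reads a 2.0-fold lower number from compound 2 to compound 3 (0.29 log units; within the scatter), so on its own it does not leave the scatter.

Compound 4 `Cc1c(-c2ccc(O)cc2)n(CCCCOc2ccccc2)c2ccccc12` is not yet measured. It stands to compound 1 as compound 3 stands to compound 2: phenoxymethyl in place of hydrogen on a saturated chain carbon, three bonds along the chain from an aromatic nitrogen. The place of the change is the same in both pairs word for word, so this is the same change made a second time, on a different core; it occurs twice among the compounds shown.

The expectation for compound 4 rests on that single earlier step. Because a 2.0-fold lower number from compound 2 to compound 3 (0.29 log units; within the scatter) stayed inside the scatter, a step of about the same size is expected here, namely a 2.0-fold lower number from compound 1 to compound 4 (0.30 log units; within the scatter). Compound 4 is therefore estimated at 4500 nM in this assay, with a range from 2000 nM to 10000 nM, the width reflecting that one prior instance on another core is a thin basis.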

Compound 4, concentration for 50% growth inhibition: 3100 nM
Compound 4: the middle estimate sits 1.5-fold (0.16 log units) above what was measured; the measured number falls inside the stated range.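

In this assay the phenoxymethyl change on the saturated chain goes the same way on both cores, and the two steps do not separate in size: the same change on two cores in this assay, a 2.0-fold lower number (0.29 log units; within the scatter) from compound 2 to compound 3 and a 2.9-fold lower number (0.46 log units; beyond the scatter) from compound 1 to compound 4, 1.5-fold (0.17 log units) apart, within the scatter of two such steps.

The new step reads a 2.9-fold lower number from compound 1 to compound 4 (0.46 log units; beyond the scatter) and so, taken alone, clears the scatter, which the earlier step on the other core does not; this difference in standing is no evidence that the core of compound 1 responds more strongly, given that the two steps stay within the scatter of each other. The result supports carrying this one change across these two cores in this one assay, but two pairs do not show that it would hold on a further core, and they say nothing about why the number falls.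

The compounds shown leave open whether the gain depends on the phenoxymethyl group itself or would also appear with a plain longer chain, or with an amine or a carboxylic acid at the chain end. Also open, as far as these compounds go, is how a substituted phenoxy ring, for example one carrying fluorine, would read on either core.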